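A few compounds are considered here, and "the series" means these few. Any claim that something is new, unique, unknown or untested is made for them only; others in the source may bear on it.

Measured compounds:
compound 1, `CCN(Cc1cccs1)C(=O)COc1ccc(C(=O)O)cc1`: "not active" (no number reported)
compound 2, `Cc1ccc(OCC(=O)N(Cc2cccs2)c2ccnn2C)cc1`: 422 nM

In an assay on HEK293 cells for agonist activity at transient receptor potential cation channel subfamily M member 8 (Homo sapiens), read by fluorescence and calcium flux, with a stated time of 15 min (a higher number here means that more compound is needed for the effect, a lower number that less compound is needed), compound 1 is recorded as "not active" (no number reported), with no number attached. Compound 2 gives 422 nM in this assay, the only numerical result in this set, so it stands alone as the reference point; compound 1 offers no value to set beside it.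

Compound 3, `Cc1ccc(OCC(=O)N(Cc2cccs2)c2nccs2)cc1`, has not yet been measured. It differs from compound 2 in a single place: 1,3-thiazol-2-yl in place of 1-methyl-1H-pyrazol-5-yl on an amide-type nitrogen. Both groups are five-membered aromatic rings with two hetero atoms and two hydrogen-bond acceptors, and the entering ring has one heavy atom fewer. Among the measured compounds shown here, no measured pair shows what such a swap does here, so the expected step in this assay is small, within the usual scatter, without a clear direction.

Compound 3 is therefore estimated at about 500 nM in this assay, between 150 nM and 2000 nM. This estimate amounts to a step of a 1.2-fold higher number from compound 2 to compound 3 (0.07 log units; within the scatter), expected to stay inside the scatter.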

Compound 3, half-maximal effective concentration: 2240 nM
Beside the measured number, compound 3's estimate is 4.5-fold (0.65 log units) below it; measured number above the stated range.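

In this assay, the ring on the amide-type nitrogen proves to matter: 1,3-thiazol-2-yl in place of 1-methyl-1H-pyrazol-5-yl gives a 5.3-fold higher number from compound 2 to compound 3 (0.72 log units; beyond the scatter) and so more compound is needed for the effect. The two groups match in ring size, in the number of hetero atoms and in the number of hydrogen-bond acceptors, yet they are not interchangeable at this place, so those shared counts alone do not settle the result. Nothing available here explains why the two rings differ.

From the compounds shown here alone, it remains open how a six-membered ring such as phenyl or pyridin-2-yl, or a simple propyl chain, would fare on this nitrogen. Also open, going by these compounds, is whether the methyl group of the 1-methyl-1H-pyrazol-5-yl ring counts, a question that the same ring without its methyl group could answer.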